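The source may hold more compounds than are shown below. What is called first, only, known or untested is meant among the compounds shown, and "the series" means these compounds.

Measured so far:
- compound 1 `CC(C)c1cccc2nc(N3CCN(C)CC3)oc12`: < 4
- compound 2 `CN1CCN(c2nc3cc(N)ccc3o2)CC1`: 4.97

Both compounds were tested in a functional assay on ileum (strain Hartley) for agonist activity at 5-hydroxytryptamine receptor 3A (Cavia porcellus); on this read-out lower numbers stand for lower potency and higher numbers for higher potency (the scale is a negative logarithm). Compound 1 gives < 4, which is a limit of the assay rather than a measured number. Compound 2 gives 4.97 in this assay. For the measured compounds named here, because of the limit of < 4 in this assay, at which 1 of the 2 values shown sits, only a ceiling is known for compound 1, and no step between the two measured compounds can be read, since they differ in more than one place.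

Compound 3 `CCc1cccc2nc(N3CCN(C)CC3)oc12` has not yet been measured in this assay. It differs from compound 1 by hydrogen in place of methyl on a saturated chain carbon bound to an aromatic carbon and a saturated chain carbon. Going by the values given here, with the shared core otherwise unchanged, the change is small, and nothing among the measured compounds points to a large shift in either direction. The expected step of a number no lower from compound 1 to compound 3 (the limit leaves the size open) is estimated to stay within the usual scatter. Compound 3 is therefore expected to give about 4, within a range from 3.5 to 4.7, so that the assay may again report only a limit.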

Compound 3, negative logarithm of the half-maximal effective concentration: 5.48
Compound 3: middle estimate off by 1.48 log units, on the low side; measured number outside the range, above it.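

The earlier compounds shown here offered no readable step, so they could not show whether this place on the shared core matters for potency. Now a single change, isopropyl to ethyl, gives in this assay a number at least 1.48 log units higher from compound 1 to compound 3 (beyond the scatter), so removing one methyl on a saturated chain carbon bound to an aromatic carbon and a saturated chain carbon is enough to produce a large step in this pair. The full size of that step stays unknown because it starts from a limit rather than a number: the limit of < 4 in this assay, at which 1 of the 3 values shown sits.

What the compounds shown leave open is whether the trend continues or reverses as this group changes further, since two compounds give only one step and no pattern along a series. A straight propyl chain, a cyclopropyl ring or a bare hydrogen in place of the ethyl group would help to show whether potency depends on the length of the chain, on its branching or on some other feature of the group.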